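A few compounds are considered here, and "the series" means these few. Any claim that something is new, unique, unknown or untested is made for them only; others in the source may bear on it.

Series notes. Compound 3 `CN(C)CN1C(=O)C(=O)c2c(Br)cccc21` is the bromo-bearing dioxo analogue carrying a (dimethylamino)methyl group on the ring nitrogen; in a functional assay on MDA-MB-231 cells (Homo sapiens) for cytotoxicity, read by sulforhodamine B assay, with a stated time of 48 h (on this read-out higher numbers stand for weaker inhibition of growth and lower numbers for stronger inhibition of growth), compound 3 gives 93700 nM, the highest number among the three measured compounds. Compound 2 `Cc1ccc2nc(/N=C3\C(=O)N(CN4CCCCC4)c4ccccc43)sc2c1` gives in this assay 34500 nM, and compound 1 `CCN(CC)CN1C(=O)/C(=N\c2nc3ccc(C)cc3s2)c2c(Br)cccc21` gives in this assay 28700 nM. Both of these sit below compound 3 by more than the usual scatter, so compound 3 is the weakest of the three on this read-out. Compound 1 and compound 2 each differ from compound 3 in more than one place, so no single-change comparison among the measured compounds is available.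

Compound 4 `CCN(CC)CN1C(=O)C(=O)c2c(Br)cccc21` is not yet measured. It differs from compound 3 by diethylamino in place of dimethylamino on a saturated chain carbon bound to an amide-type nitrogen in a ring. For the measured compounds named here, no measured pair isolates this change; compound 1 carries the diethylamino group but also differs elsewhere in the core, so its value cannot be read as a guide. The change is expected to move this assay little, by a 1.2-fold lower number from compound 3 to compound 4 (0.07 log units; within the scatter), not beyond the scatter. For compound 4 in this assay the estimate is 80000 nM, with a range from 35000 nM to 190000 nM.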

Compound 4, concentration for 50% growth inhibition: 20200 nM
For compound 4 the middle estimate is 4.0-fold (0.60 log units) above the measured one; the measured number lies below the stated range.
By their numbers in this assay, from the lowest: compounds 4, 1 and 2 (each within the scatter of the next); then compound 3.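

For the compounds shown here, compound 3 and compound 4 give the first single-change comparison: in this assay, diethylamino in place of dimethylamino on a saturated chain carbon bound to an amide-type nitrogen in a ring gives a 4.6-fold lower number from compound 3 to compound 4 (0.67 log units; beyond the scatter), a step beyond the usual scatter. The amine at the end of this chain therefore affects the read-out on this core, even though the change is confined to this one group. The data shown offer no measured explanation for the step.

Going by these compounds, it remains open how this position would respond to a dipropylamino group or morpholine on the same chain carbon. It is also unknown whether the same change would give a similar step on the core of compound 1, as no dimethylamino partner of that compound is shown.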